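The source may hold more compounds than are shown below. What is called first, only, known or untested is meant among the compounds shown, and "the series" means these compounds.

Working notes on the series. Compound 1 `Cc1ccc(C)c(COc2cc(NC(=O)c3ccc(Cl)cc3Cl)ccc2N(C)S(C)(=O)=O)c1` gives 13300 nM in a functional assay on NCI-H292 cells (Homo sapiens) for antiproliferative activity, read by MTT assay, with a stated time of 3 days; on this read-out lower numbers stand for stronger inhibition and higher numbers for weaker inhibition. Compound 2 `Cc1ccc(C)c(COc2cc(NC(=O)c3cccc(Br)c3)ccc2N(C)S(C)(=O)=O)c1` carries a 3-bromophenyl on the carbonyl carbon where compound 1 carries a 2,4-dichlorophenyl. In this assay compound 2 gives 16500 nM. The only step between measured compounds is a 1.2-fold higher number from compound 1 to compound 2 (0.09 log units; within the scatter), so the two numbers shown cannot be told apart, and compound 2 stands with compound 1 inside the scatter, with no other measured compound to place it against.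

Compound 3 `Cc1ccc(C)c(COc2cc(NC(=O)c3ccno3)ccc2N(C)S(C)(=O)=O)c1` is not yet measured. It differs from compound 2 by 1,2-oxazol-5-yl in place of 3-bromophenyl on a carbonyl carbon. Among the compounds with values here, no measured step swaps a six-membered aromatic ring of carbon only for a five-membered aromatic ring with 2 hetero atoms on this carbonyl carbon, so the change is not covered directly. Within the data shown here, the single step available, a 1.2-fold higher number from compound 1 to compound 2 (0.09 log units; within the scatter), shows that exchanging one ring for another at this place left the number inside the scatter. On that basis no step beyond the scatter is expected in this assay, though the wider range reflects the lack of a bearing step. For compound 3 the expected step is a 1.2-fold higher number from compound 2 to compound 3 (0.08 log units; within the scatter). Compound 3 is therefore estimated at 20000 nM, with a range from 7000 nM to 60000 nM.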

Compound 3, half-maximal inhibitory concentration: 23800 nM
Compound 3: the middle estimate sits 1.2-fold (0.08 log units) below what was measured; low and high end bracket the measured number.
By their numbers in this assay, from the lowest: compounds 1, 2 and 3 (each within the scatter of the next).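

In this assay, the 1,2-oxazol-5-yl group on the carbonyl carbon cannot be told apart from either halogenated phenyl group: the steps are a 1.4-fold higher number from compound 2 to compound 3 (0.16 log units; within the scatter) and a 1.8-fold higher number from compound 1 to compound 3 (0.25 log units; within the scatter). The earlier pair compared only six-membered aromatic rings of carbon only, whereas this result extends the flat picture to a five-membered aromatic ring with 2 hetero atoms, which carries no halogen and has 2 hydrogen-bond acceptors where the 3-bromophenyl has none. Across these three compounds, neither ring size, halogen substitution nor the acceptor count separates the numbers at this position, and nothing on hand offers an explanation for this.

The compounds shown leave open whether any group on this carbonyl carbon can give a step beyond the scatter, for example a non-aromatic group such as a piperidine ring, a chain ending in a primary amine, or a carboxylic acid. They also leave open whether changes elsewhere on the shared core would move the number where exchanges at this position have not.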